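A few compounds are considered here, and "the series" means these few. Any claim that something is new, unique, unknown or untested is made for them only; others in the source may bear on it.

Measured so far:
compound 1 `O=C(O)c1ccc(OCc2ccccc2)cc1O`: in an ADME assay on NCI-H630 cells (Homo sapiens) for cytotoxicity, read by MTT assay, with a stated time of 72 h (a higher number here means that more compound is tolerated, a lower number that less compound is tolerated), compound 1 gives > 40000 nM, which is a limit of the assay rather than a number.
compound 2 `O=C(NCc1cccc2ccccc12)c1cccc(O)c1O`: in this assay compound 2 gives 21000 nM.
compound 3 `O=C(NCc1ccco1)c1cc(S(=O)(=O)N2CCCCC2)cc(O)c1O`: in this assay compound 3 gives 33000 nM.

Among the two actual numbers, compound 3 and compound 2 lie within the usual scatter of each other, so neither can be placed above the other. Compound 4 `O=C(NCc1cccs1)c1cc(S(=O)(=O)N2CCCCC2)cc(O)c1O` differs from compound 3 in one place: thiophen-2-yl in place of furan-2-yl on a saturated chain carbon bound to an amide-type nitrogen. Among the measured compounds shown here, no measured pair shows such a swap, so the expected step in this assay from compound 3 to compound 4 is none beyond the scatter, in either direction. Compound 4 is therefore estimated at 33000 nM, expected to fall between 15000 nM and 70000 nM, a step of no change at the digits printed from compound 3 to compound 4 (within the scatter).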

Compound 4, half-maximal cytotoxic concentration: > 40000 nM
Compound 4: only a limit was reported; the forecaster's own chance of this, stated with the estimate: 35%; middle value at least 1.2-fold (0.08 log units) away from the limit.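

Among the compounds shown here, the first comparison of compounds that differ in one place in this assay gives an at least 1.2-fold higher number from compound 3 to compound 4 (0.08 log units; that floor lies within the scatter) on swapping furan-2-yl for thiophen-2-yl on a saturated chain carbon bound to an amide-type nitrogen. Tolerance shows no drop with this swap, but how far it rises cannot be read, because the value of compound 4 is a limit of the assay and not a number: the limit of > 40000 nM in this assay, at which 2 of the 4 values shown sit.

Going by these compounds, whether an amine, a carboxylic acid or a longer chain at this place would keep that tolerance stays open. So does whether this swap would act alike on another core.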